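Moving a Fluorine on an Aryl Sulfonamide

The source may hold more compounds than are shown below. What is called first, only, known or untested is meant among the compounds shown, and "the series" means these compounds.

Measured compounds:
compound 1, `CCc1ccc(N(CC(C)C)S(=O)(=O)c2ccc(OCC3CCOCC3)c(CN)c2)cc1`: 3.25
compound 2, `CC(C)CN(c1cccc(F)c1)S(=O)(=O)c1ccc2c(c1)C(O)CC(C1CCOCC1)O2`: 3.39

Both compounds were measured in a physicochemical assay for lipophilicity, at pH 7.4; on this read-out lower numbers stand for lower lipophilicity and higher numbers for higher lipophilicity. Compound 2 has the higher of the two numbers, yet its gap to compound 1 lies within the usual scatter of repeated measurements, so the two compounds cannot be told apart on this read-out.

Compound 3 `CC(C)CN(c1ccccc1F)S(=O)(=O)c1ccc2c(c1)C(O)CC(C1CCOCC1)O2` has not been measured. It differs from compound 2 in a single place: 2-fluorophenyl in place of 3-fluorophenyl on a sulfonamide nitrogen. The fluorine stays, the ring stays, and only its position on the ring shifts. For the measured compounds named here, no step between measured compounds speaks to a change of this kind, so the expectation rests on how little is changed. The expected step of a number 0.09 log units lower from compound 2 to compound 3 (within the scatter) should stay within the scatter, with no clear direction. In this assay compound 3 is therefore estimated at 3.3, with a range from 2.9 to 3.7.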

Compound 3, distribution coefficient: 3.39
Estimate against measurement, compound 3: 0.09 log units below, and the stated range covers the measured number.
By their numbers in this assay, from the lowest: compounds 1, 2 and 3 (each within the scatter of the next).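

For the compounds shown here, putting 2-fluorophenyl in place of 3-fluorophenyl on a sulfonamide nitrogen gives no change at the digits printed from compound 2 to compound 3 (within the scatter) in this assay, and this is the first pair here that differs in one place only. Going by these compounds alone, it gives the first direct reading at this position: for this pair, where the fluorine sits on the ring does not separate the two compounds on this read-out, something the comparison with compound 1, which differs in several places, could not show. Nothing measured here bears on why the number holds steady.

The pair covers only two placements of one fluorine on one shared core, so it leaves open whether the same swap would behave alike on another core. It also leaves open how far the number would move with a different group on that ring, such as an amine or a carboxylic acid.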